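Same atoms, rejoined: compound 4 against compound 1

The compounds below may be only part of what the source reports. "The series", "measured", "known", "first", "only" and "open" are said of these compounds alone.

Three esters of the shared core have been read in an ADME assay on cells (T-cell, Mus musculus, strain BALB/c) for cytotoxicity, read by MTT assay, with a stated time of 48 h; on this read-out higher numbers stand for lower toxicity in this test and lower numbers for higher toxicity in this test. Compound 1 `COC(=O)c1ccc(C)cc1OC(=O)COc1cc(O)c2c(=O)cc(-c3ccccc3)oc2c1` gives 250000 nM; compound 2 `COC(=O)c1cccc(Cl)c1OC(=O)COc1cc(O)c2c(=O)cc(-c3ccccc3)oc2c1` gives 366000 nM; compound 3 `COC(=O)c1cccc(OC)c1OC(=O)COc1cc(O)c2c(=O)cc(-c3ccccc3)oc2c1` gives 196000 nM. Compound 1 lies within the scatter of both neighbours, nearest to compound 3 and furthest from compound 2, so no order among the three can be claimed. The step from compound 1 to compound 2 was a 1.5-fold higher number from compound 1 to compound 2 (0.17 log units; within the scatter) and that from compound 2 to compound 3 was a 1.9-fold lower number from compound 2 to compound 3 (0.27 log units; within the scatter); neither left the scatter.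

Compound 4 `COC(=O)c1cc(C)ccc1OC(=O)COc1cc(O)c2c(=O)cc(-c3ccccc3)oc2c1` differs from compound 1 by a group of 11 heavy atoms (9 carbon, 2 oxygen; one six-membered aromatic ring of carbon only) in place of a group of 11 heavy atoms (9 carbon, 2 oxygen; one six-membered aromatic ring of carbon only), on an oxygen next to a carbonyl group; the two have the same atoms, joined differently. With both measured changes at this oxygen next to a carbonyl group staying within the scatter, no step beyond the scatter is expected in this assay for compound 4, and no change at the digits printed from compound 1 to compound 4 (within the scatter) is the estimate. Compound 4 is therefore expected to give 250000 nM, from 140000 nM to 450000 nM.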

Compound 4, half-maximal cytotoxic concentration: 306000 nM
The estimate for compound 4 lay 1.2-fold (0.09 log units) below the measured number; measured number inside the range.
By their numbers in this assay, from the lowest: compounds 3, 1, 4 and 2 (each within the scatter of the next).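

Rejoining the same atoms in the group on an oxygen next to a carbonyl group still does not leave the scatter in this assay, with a 1.2-fold higher number from compound 1 to compound 4 (0.09 log units; within the scatter) and a 1.2-fold lower number from compound 2 to compound 4 (0.08 log units; within the scatter) as the two new steps. All the changes read at this place now stay within the scatter, whether atoms are exchanged or only joined differently. Nothing measured here bears on a cause for this.

As far as these compounds go, whether an amine or a carboxylic acid in the group on this oxygen would leave the scatter remains open. Changes to the shared core also remain open.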